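Exchanging the side chain of compound 3 for a sugar

A few compounds are considered here, and "the series" means these few. Any claim that something is new, unique, unknown or untested is made for them only; others in the source may bear on it.

In a functional assay on MDA-MB-231 cells (Homo sapiens) for cytotoxicity, read by MTT assay, with a stated time of 72 h (a lower number here means a stronger inhibitor, a higher number a weaker inhibitor), compound 3 `CC1(C)OC[C@@H](Cn2cc(Cn3c4c(c5ccccc53)C(=O)c3c[n+]([O-])c5ccccc5c3C4=O)nn2)O1` gives > 1000 nM, which is a limit and not a number. Compound 2 `CC1(C)OC[C@H](Cn2cc(Cn3c4c(c5ccccc53)C(=O)c3c[n+]([O-])c5ccccc5c3C4=O)nn2)O1`, differing only in configuration as drawn, gives 530 nM, and the pair shows an at least 1.8-fold higher number from compound 2 to compound 3 (0.27 log units; that floor lies within the scatter). Compound 1 `O=C1c2c[n+]([O-])c3ccccc3c2C(=O)c2c1c1ccccc1n2Cc1cn(C[C@H](O)CO)nn1`, which carries 1,2-dihydroxyethyl instead of the dioxolane, gives 1310 nM, and the modest step to its dioxolane partner is a 2.5-fold lower number from compound 1 to compound 2 (0.39 log units; beyond the scatter). Compound 4 `O=C1c2c[n+]([O-])c3ccccc3c2C(=O)c2c1c1ccccc1n2Cc1cn([C@@H]2O[C@H](CO)[C@@H](O)[C@H](O)[C@H]2O)nn1` places 3,4,5-trihydroxy-6-(hydroxymethyl)oxan-2-yl on the aromatic nitrogen: 3,4,5-trihydroxy-6-(hydroxymethyl)oxan-2-yl in place of (2,2-dimethyl-1,3-dioxolan-4-yl)methyl on an aromatic nitrogen. Compound 1 also has free hydroxyl groups, so its 1310 nM is the nearest guide, and little change is expected. The expected step is a step that the limit leaves unreadable from compound 3 to compound 4, with only a limit as its starting point. For compound 4 the estimated value is 1500 nM, within an expected range of 600 nM to 4500 nM.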

Compound 4, half-maximal inhibitory concentration: 650 nM
Estimate against measurement, compound 4: 2.3-fold (0.36 log units) above, and the stated range covers the measured number.
By their numbers in this assay, from the lowest: compounds 2, 4 and 1 (each within the scatter of the next, the first and the last beyond it).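

On the aromatic nitrogen, 3,4,5-trihydroxy-6-(hydroxymethyl)oxan-2-yl, a larger group with more hydrogen-bond donors, stays within the scatter of both compounds with smaller groups in this assay: the steps are a 1.2-fold higher number from compound 2 to compound 4 (0.09 log units; within the scatter) and a 2.0-fold lower number from compound 1 to compound 4 (0.30 log units; within the scatter). Compound 3 has only a limit, > 1000 nM. Its step, an at least 1.5-fold lower number from compound 3 to compound 4 (0.18 log units; that floor lies within the scatter), therefore gives only a floor.

From the compounds shown here alone, what an amine or a carboxylic acid would do on this aromatic nitrogen remains open. So does the effect of a longer chain between that nitrogen and the sugar.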